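This account rests on a few compounds, and the source may have more. Where it says the series, first, only, none or still open, it means among the compounds named here.

Measured compounds in the series so far:

- compound 1, `NC1=NC2(CCOCC2)N(OCCCOc2cccc(Cl)c2)C(N)=N1`: 85.8%
- compound 2, `NC1=NC2(CCOCC2)N(OCCCOc2cc(Cl)c(Cl)cc2Cl)C(N)=N1`: "not determined" (no result reported)
- compound 3, `NC1=NC2(CCSCC2)N(OCCCOc2cccc(Cl)c2Cl)C(N)=N1`: 89.8%

In an assay on isolated protein for inhibition of Dihydrofolate reductase (Homo sapiens), read by spectrophotometry, using NADPH, with stated times of 5 s and 6 min, tested at 50 uM (on this read-out lower numbers stand for a weaker effect and higher numbers for a stronger effect at the one concentration tested), compound 1 gives 85.8%. For compound 2 the entry reads "not determined" (no result reported), so no number stands against it. In this assay compound 3 gives 89.8%. Two numbers are thus available; the gap between compound 3 and compound 1 lies within the scatter, so the two cannot be told apart on these data, and compound 2 contributes nothing to the comparison.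

Compound 4, `NC1=NC2(CCSCC2)N(OCCCOc2ccccc2Cl)C(N)=N1`, has not been measured. It differs from compound 3 in one place: hydrogen in place of chloro on an aromatic carbon. No pair of measured compounds shares this change, so there is no measured step to lean on, and the two shown numbers themselves sit within the scatter of each other. On that basis the step is expected to be small, estimated as a number 6.8 percentage points lower from compound 3 to compound 4 (within the scatter), with no change beyond the scatter anticipated in either direction. The number for compound 4 is estimated at 83%, with an expected range from 66% to 95%.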

Compound 4, a percentage reported as inhibition, at one concentration (the size of the read-out at that concentration, not a potency): 89.6%
Beside the measured number, compound 4's estimate is 6.6 percentage points below it; the measured number falls inside the stated range.
By their numbers in this assay, from the lowest: compounds 1, 4 and 3 (each within the scatter of the next).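

In this assay, within the data shown here, the change from 2,3-dichlorophenyl to 2-chlorophenyl gives a number 0.2 percentage points lower from compound 3 to compound 4 (within the scatter) as the first step that can be read at a single place. At this aromatic carbon, ortho to a chloro group and meta to a large group, hydrogen and chloro therefore cannot be told apart at the one concentration tested, although this percentage is not a potency and a difference in potency could still lie behind it. No measured evidence bears on this result.

As far as these compounds go, whether a methoxy group, a nitrile, an amine or a carboxylic acid at the same carbon would give a step beyond the scatter remains open, as does the outcome of replacing the remaining chloro group with hydrogen to leave a plain phenyl ring. Also open, from the compounds shown here alone, is whether the same hydrogen-for-chloro change would give a similar step on the core of compound 1, since this single step was read only on the core shared by compound 3 and compound 4.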